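Removing the Sulfur Methyl in a Cytotoxicity Series

The source may report more compounds than this note shows. Statements on the series, on what has been measured and on what is new or still open speak of the compounds shown alone.

Measured compounds, in a functional assay on CCRF-CEM cells (Homo sapiens) for cytotoxicity, read by MTT assay, with a stated time of 72 h; a lower number here means that less compound is tolerated, a higher number that more compound is tolerated:
compound 1 `COc1ccc(CNc2nc(SC)nc3ccccc23)cc1`: > 100000 nM
compound 3 `CSc1nc(NCc2ccccc2)c2ccccc2n1`: > 100000 nM
compound 2 `[SeH]c1nc(NCc2ccccc2)c2cccnc2n1`: > 100000 nM

Compound 1 gives only a limit of the assay, > 100000 nM, so its standing is known only as a bound and not as a number. Compound 3 likewise gives only a limit, > 100000 nM. Compound 2, which has a different core and a selenol in place of the methylsulfanyl, also gives only a limit, > 100000 nM. The step from compound 1 to compound 3, a step that the two limits leave unreadable from compound 1 to compound 3, cannot be sized, since both ends sit at the limit of > 100000 nM in this assay, at which 3 of the 3 values shown sit.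

Compound 4 `COc1ccc(CNc2nc(S)nc3ccccc23)cc1` is the one not yet measured. It differs from compound 1 by hydrogen in place of methyl on a sulfur. Among the measured compounds shown here, no measured step touches this change; the only step at hand, from compound 1 to compound 3, is unreadable, and compound 2 carries the related sulfanyl-like change on another core and also sits at the limit. With every measured value at the limit, no shift beyond the scatter is expected in this assay in either direction. Compound 4 is therefore estimated at 150000 nM, with a range from 40000 nM to 600000 nM, and a step from compound 1 of a step that the limit leaves unreadable from compound 1 to compound 4 is expected, most likely reported again only as a limit.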

Compound 4, concentration lethal to 50% of the cells: 71600 nM
Beside the measured number, compound 4's estimate is 2.1-fold (0.32 log units) above it; low and high end bracket the measured number.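

In this assay compound 4, which carries sulfanyl where compound 1 carries methylsulfanyl, is the only compound shown that reads as a number and not as a limit of the assay: the limit of > 100000 nM in this assay, at which 3 of the 4 values shown sit. Hydrogen in place of methyl on this sulfur gives an at least 1.3-fold lower number from compound 1 to compound 4 (0.14 log units; that floor lies within the scatter), so this change is the one place in the series where a step can be read at all, although the floor printed with it does not by itself establish a shift beyond the scatter. The other steps among these compounds cannot be read, so the sulfur whose other neighbour is an aromatic carbon is the only position for which the data hold any reading.

Going by these compounds, it remains open how far compound 4 really lies from compound 1, since only a floor is known, and whether the sulfanyl would give a number without the methoxy that compound 4 also carries. Also open, on these data alone, is whether an ethyl on this sulfur, or an amine in place of the sulfanyl, would keep a measurable number or return to the limit.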